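Methoxy in place of fluoro: three quiet neighbours so far

A few compounds are considered here, and "the series" means these few. Any claim that something is new, unique, unknown or untested is made for them only; others in the source may bear on it.

Of the compounds shown here, three sharing one core have been tested in an ADME assay on Vero cells (Chlorocebus sabaeus) for cytotoxicity, read by neutral red uptake, tested at 49 ug/mL; a higher number here means a weaker effect of the compound at the concentration tested, a lower number a stronger effect. Compound 1 `O=C1CSC(c2cccc(Cl)c2)N1CCN1CCCCC1` gives 100%. Compound 2 `O=C1CSC(c2cccc(O)c2)N1CCN1CCCCC1` gives 100%. Compound 3 `O=C1CSC(c2cccc(F)c2)N1CCN1CCCCC1` gives 97%. Compound 3 stands in the same place as its two neighbours: a number 3 percentage points lower from compound 1 to compound 3 (within the scatter), and a number 3 percentage points lower from compound 2 to compound 3 (within the scatter). The third pairing is of the same kind, since no change at the digits printed from compound 1 to compound 2 (within the scatter).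

The next compound, compound 4 `COc1cccc(C2SCC(=O)N2CCN2CCCCC2)c1`, differs from compound 3 by methoxy in place of fluoro on an aromatic carbon.

Every measured step bears on this in the same loose way: each swaps one small group for another at the same aromatic carbon, and every one of them stayed within the scatter, whether chloro became hydroxy, chloro became fluoro, or hydroxy became fluoro. A methoxy group has not been tried, so the closest guidance is that three different substituents at this position left the read-out essentially where it was. On that basis the expected step is no change at the digits printed from compound 3 to compound 4 (within the scatter), which is to say none beyond the scatter. Compound 4 is therefore estimated at 97%, with a range from 85% to 100%.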

Compound 4, a percentage reported as activity, at one concentration (the size of the read-out at that concentration, not a potency): 90%
Compound 4: the middle estimate sits 7 percentage points above what was measured; the measured number falls inside the stated range.
By their numbers in this assay, from the lowest: compounds 4, 3, 1 and 2 (each within the scatter of the next).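

Methoxy brings 2 heavy atoms and a hydrogen-bond acceptor to this aromatic carbon, where fluoro brought neither an extra atom nor an acceptor, and in this assay the step still stays inside the usual scatter (a number 7 percentage points lower from compound 3 to compound 4 (within the scatter)). Comparing methoxy with the other two groups gives the largest steps in this small set, yet both are also printed as within the scatter, whether a methyl caps the oxygen of the hydroxy group (a number 10 percentage points lower from compound 2 to compound 4 (within the scatter)) or methoxy takes the place of chloro (a number 10 percentage points lower from compound 1 to compound 4 (within the scatter)), so compounds 1 to 4 show no step beyond the scatter and none of them goes against that picture. Nothing among the data shown offers an explanation for these numbers.

As far as these compounds go, whether an amine, a carboxylic acid or a longer chain such as butoxy at this aromatic carbon would also leave the read-out in place remains open. From the compounds shown here alone, it is equally open whether methoxy would behave this way on another carbon of the aromatic ring, or whether a different amine at the end of the side chain would shift the number.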